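Aryl exchange from compound 1 to compound 4

The compounds below may be only part of what the source reports. "The series", "measured", "known", "first", "only" and "open" are said of these compounds alone.

For the measured compounds named here, in a functional assay on A549 cells (Homo sapiens) for inhibition, read by MTT assay, with a stated time of 48 h (on this read-out higher numbers stand for weaker inhibition and lower numbers for stronger inhibition), compound 1 `COc1cc(/C=N/Nc2nc(-c3ccc(Br)cc3)cs2)cc(Br)c1OC` gives 52300 nM and compound 2 `COc1cc(/C=N/Nc2nc(-c3ccc(Br)cc3)cs2)c(Br)c(Br)c1OC` gives 46100 nM, so the two sit together at the upper end of the three numbers so far. Compound 3 `COc1cc(/C=N/Nc2nc(-c3ccc(C(F)(F)F)cc3)cs2)cc(Br)c1OC` gives 18300 nM, under both of them.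

The next compound is compound 4 `COc1ccccc1-c1csc(N/N=C/c2cc(Br)c(OC)c(OC)c2)n1`. The change is 2-methoxyphenyl in place of 4-bromophenyl on an aromatic carbon, with 2-methoxyphenyl in place of 4-bromophenyl on an aromatic carbon of a five-membered aromatic ring with 1 nitrogen and 1 sulfur.

Two measured steps are available. The first, a 1.1-fold lower number from compound 1 to compound 2 (0.05 log units; within the scatter), is bromo in place of hydrogen on an aromatic carbon, and it says little here since it leaves the 4-bromophenyl group untouched. The second, a 2.9-fold lower number from compound 1 to compound 3 (0.46 log units; beyond the scatter), is trifluoromethyl in place of bromo on an aromatic carbon. It is the closer precedent, as it also alters the 4-bromophenyl group, and it is modest in size.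

Going by the values given here, no measured compound carries 2-methoxyphenyl, so the precedent is indirect. A downward step smaller than that second one is expected, and it may not clear the scatter. The estimated step is a 1.7-fold lower number from compound 1 to compound 4 (0.24 log units; within the scatter). For compound 4 the estimated value is 30000 nM, with an expected range of 11000 nM to 80000 nM.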

Compound 4, half-maximal inhibitory concentration: 94900 nM
Beside the measured number, compound 4's estimate is 3.2-fold (0.50 log units) below it; measured number outside the range, above it.
By their numbers in this assay, from the lowest: compound 3; then compounds 2, 1 and 4 (each within the scatter of the next, the first and the last beyond it).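

Working notes on the aryl group. In this assay the exchange of 4-bromophenyl for 2-methoxyphenyl, on the aromatic carbon next to the ring nitrogen, gives a 1.8-fold higher number from compound 1 to compound 4 (0.26 log units; within the scatter) and so leaves no difference that can be separated from assay noise. For the compounds shown here, this position therefore accepts a different aryl group, one that adds a hydrogen-bond acceptor and loses the bromine, without a step beyond the scatter, whereas the exchange of bromo for trifluoromethyl on the same phenyl ring gave a 2.9-fold lower number from compound 1 to compound 3 (0.46 log units; beyond the scatter) as the one step at this group that clears it. Compound 3 at 18300 nM and compound 4 at 94900 nM differ only in this aryl group and stand at the two ends of the series, so the range seen so far in this assay is spanned by changes at this one carbon.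

Nothing on hand explains why these aryl groups give these numbers. Open, going by these compounds, is how an amine or a carboxylic acid on this phenyl ring, or plain unsubstituted phenyl, would read here, and whether 2-methoxyphenyl behaves the same way alongside the dibromo pattern of compound 2.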